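A methoxy group moves on the phenyl ring

This account rests on a few compounds, and the source may have more. Where it says the series, first, only, none or still open, it means among the compounds named here.

Within the data shown here, in a functional assay on MDA-MB-231 cells (Homo sapiens) for cytotoxicity, read by MTT assay, with a stated time of 72 h (on this read-out lower numbers stand for stronger inhibition and higher numbers for weaker inhibition), compound 3 `COc1cccc(CSc2nnc(-c3c[nH]c4ccccc34)n2N)c1` gives 15600 nM, the highest number so far and so the weakest result. Compound 1 `Nn1c(SCc2ccc([N+](=O)[O-])cc2)nnc1-c1c[nH]c2ccccc12` gives 740 nM, and compound 2 `Nn1c(SCc2ccc(F)cc2)nnc1-c1c[nH]c2ccccc12` gives 1350 nM. Replacing nitro with fluoro gave a 1.8-fold higher number from compound 1 to compound 2 (0.26 log units; within the scatter). Compound 4 `COc1ccc(CSc2nnc(-c3c[nH]c4ccccc34)n2N)cc1` carries 4-methoxyphenyl in place of 3-methoxyphenyl on a saturated chain carbon bound to a sulfur. Among the measured compounds shown here, no measured step moves a methoxy group alone. The nearest guide is a 12-fold higher number from compound 2 to compound 3 (1.06 log units; beyond the scatter), which changed the group and its place together. Part of that large rise may therefore reverse, so a lower number is expected. The expected step is a 3.1-fold lower number from compound 3 to compound 4 (0.49 log units; beyond the scatter). For compound 4 the estimated value is 5000 nM, with an expected range of 1300 nM to 16000 nM.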

Compound 4, half-maximal inhibitory concentration: 1700 nM
Compound 4: the middle estimate sits 2.9-fold (0.47 log units) above what was measured; the range from low to high includes it.
By their numbers in this assay, from the lowest: compounds 1, 2 and 4 (each within the scatter of the next, the first and the last beyond it); then compound 3.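

Moving the methoxy group alone gives a 9.2-fold lower number from compound 3 to compound 4 (0.96 log units; beyond the scatter) in this assay and shows that the place of this group on the phenyl ring counts, not only its identity. Methoxy in place of fluoro gives a 1.3-fold higher number from compound 2 to compound 4 (0.10 log units; within the scatter) while methoxy in place of nitro gives a 2.3-fold higher number from compound 1 to compound 4 (0.36 log units; beyond the scatter) and so 4-methoxyphenyl, unlike 3-methoxyphenyl, stays close to the 4-fluorophenyl group. Nothing shown gives a reason for this.

On these data alone, whether moving fluoro or nitro has as large an effect stays open. So does whether an amine or a carboxylic acid on the phenyl ring, or a longer chain to the sulfur, would give a lower number.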